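The source may report more compounds than this note shows. Statements on the series, on what has been measured and on what is new or still open speak of the compounds shown alone.

Compound 1 `O=c1c(-c2nn[nH]n2)c[nH]c2ccccc12` is the anchor of the series. For the measured compounds named here, in a functional assay on the whole organism (strain Sprague-Dawley) for inhibition, with Rattus norvegicus as the target (on this read-out lower numbers stand for an effect already at smaller amounts and higher numbers for an effect only at larger amounts of compound), compound 1 gives 1.25 mg/kg, the only plain number among the three values in hand. Compound 2 `O=c1c(-c2nn[nH]n2)c[nH]c2ccc(Cl)cc12` carries a chloro in place of hydrogen on an aromatic carbon, and in this assay compound 2 reaches only > 10 mg/kg, which is a limit of the assay rather than a number. The step of an at least 8.0-fold higher number from compound 1 to compound 2 (0.90 log units; beyond the scatter) therefore rests on (the limit of > 10 mg/kg in this assay, at which 1 of the 3 values shown sits). Compound 3 `CCc1ccc2c(=O)c(-c3nn[nH]n3)c[nH]c2c1` carries an ethyl in place of hydrogen on an aromatic carbon, and in this assay compound 3 gives < 5 mg/kg, again a limit rather than a number. The step that the limit leaves unreadable from compound 1 to compound 3 stays unreadable because of the limit of < 5 mg/kg in this assay, at which 1 of the 3 values shown sits.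

Compound 4 `Cc1cccc2c(=O)c(-c3nn[nH]n3)c[nH]c12` has not been measured. It differs from compound 1 in one place: methyl in place of hydrogen on an aromatic carbon. The closest measured change, the ethyl step to compound 3, gives no readable size, while the chloro step to compound 2 shows a ring substituent raising the dose at least modestly. In this assay compound 4 is therefore expected to give about 2.5 mg/kg, within a range from 1 mg/kg to 10 mg/kg. The step this estimate implies, a 2.0-fold higher number from compound 1 to compound 4 (0.30 log units; within the scatter), is expected to be small, possibly within the scatter.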

Compound 4, minimum effective dose: > 5 mg/kg
Compound 4: only a limit was reported; the forecaster's own chance of this, stated with the estimate: 30%; at least 2.0-fold (0.30 log units) between middle value and limit.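

In this assay, methyl on this aromatic carbon, ortho to a fused ring, brings an at least 4.0-fold higher number from compound 1 to compound 4 (0.60 log units; beyond the scatter), so a group of only 1 heavy atom is enough to move the result beyond the usual scatter. This size is only a lower bound, since the value of compound 4 is a limit and not a number: the limit of > 5 mg/kg in this assay, at which 1 of the 4 values shown sits. With an at least 8.0-fold higher number from compound 1 to compound 2 (0.90 log units; beyond the scatter), there are now two places on the core of compound 1 where a new group goes with a higher number, while the ethyl step to compound 3 cannot be read and neither supports nor goes against this.

As far as these compounds go, how much higher the true value of compound 4 lies remains open. Also open, from the compounds shown here alone, is whether a fluorine atom, an amine or a methoxy group on this same carbon would behave like methyl.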